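Cyclising the amide: piperidine in place of diethylamine

This account rests on a few compounds, and the source may have more. Where it says the series, first, only, none or still open, it means among the compounds named here.

Three pyrazole amides sharing one core have been tested in a functional assay on the whole organism (strain Wistar) for inhibition, with Rattus norvegicus as the target, read by paw edema, with stated times of 30 min and 3 h, at a dose of 100 mg/kg by the oral route; a higher number here means more inhibition at the dose given (going by the name of the read-out), a lower number less inhibition. Compound 1 `COc1cc(C(=O)N2CCCCC2)nn1-c1ccccc1` gives 28.2%, compound 2 `CCCCNC(=O)c1cc(OCCCC)n(-c2ccccc2)n1` gives 43.3%, and compound 3 `CCCCOc1cc(C(=O)N(CC)CC)nn1-c1ccccc1` gives 44.1%. Compound 3 has the highest number of the three; compound 2 sits within the scatter of it, while compound 1 lies well below it. Compound 4 `CCCCOc1cc(C(=O)N2CCCCC2)nn1-c1ccccc1` differs from compound 3 by piperidin-1-yl in place of diethylamino on a carbonyl carbon. Among the measured compounds shown here, the only step on the amide side, a number 0.8 percentage points higher from compound 2 to compound 3 (within the scatter), was within the scatter, so the number stayed level across that swap at the amide nitrogen. Compound 1, which carries piperidin-1-yl with a methoxy group, is the only other hint and sits low. A step of a number 5.1 percentage points lower from compound 3 to compound 4 (within the scatter) is expected, within the scatter, so compound 4 is estimated at 39%, ranging from 24% to 54%.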

Compound 4, a percentage reported as inhibition, in the whole organism at one dose (the size of the read-out at that dose, not a potency): 15.6%
Compound 4: the middle estimate sits 23.4 percentage points above what was measured; measured number below the stated range.
By their numbers in this assay, from the lowest: compound 4; then compound 1; then compounds 2 and 3 (each within the scatter of the next).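

Closing the amide into a ring matters here: a number 28.5 percentage points lower from compound 3 to compound 4 (beyond the scatter) and a number 27.7 percentage points lower from compound 2 to compound 4 (beyond the scatter) in this assay show that piperidin-1-yl on the carbonyl carbon does not behave like the open-chain amides. With piperidin-1-yl held fixed, adding propyl in place of hydrogen on the chain bound to the oxygen also gives less inhibition, with a number 12.6 percentage points lower from compound 1 to compound 4 (beyond the scatter) as the step. Nothing available explains either drop. Still open, on these data alone, is whether pyrrolidin-1-yl or morpholin-4-yl on the same carbonyl carbon would give a similarly low number. Also open, as far as these compounds go, is whether the diethylamino amide would respond in the same way to a methoxy group.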